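Swapping a pyridine for fluorophenyl on a styryl chromone

The source may report more compounds than this note shows. Statements on the series, on what has been measured and on what is new or still open speak of the compounds shown alone.

Compound 1, `COc1cc(OC)c2c(=O)cc(/C=C/c3ccncc3)oc2c1`, gives > 40000 nM in a functional assay on SKHep cells (Homo sapiens) for antiproliferative activity, read by MTT assay, with a stated time of 12 h (a higher number here means a weaker inhibitor, a lower number a stronger inhibitor), a limit of the assay rather than a number.
Compound 2, `COc1ccc2c(=O)cc(/C=C/c3ccc(OC(F)(F)F)cc3)oc2c1`, gives > 40000 nM in this assay, again a limit.
Compound 3, `COc1cc(OC)c2c(=O)cc(/C=C/c3ccc(C(F)(F)F)cc3)oc2c1`, gives 20600 nM in this assay.

Compound 1 therefore stands at the limit of this assay, and two of the three values shown sit there (the limit of > 40000 nM in this assay, at which 2 of the 3 values shown sit). Only compound 3 returns a number, and that number is itself weak. Compound 4, `COc1cc(OC)c2c(=O)cc(/C=C/c3ccc(F)cc3)oc2c1`, has not yet been measured; it differs from compound 1 in one place: 4-fluorophenyl in place of pyridin-4-yl on a double-bonded chain carbon bound to a double-bonded chain carbon. Within the data shown here, no step between measured compounds exists for this change, so there is no measured comparison to draw on. Compound 3 shows that a trifluoromethyl-bearing phenyl group on the shared core yields a measurable but weak value, and compound 4 carries a phenyl group of related type, so a value near that of compound 3, or a limit, is expected. The step from compound 1 to compound 4 is estimated at an at least 1.3-fold lower number from compound 1 to compound 4 (0.12 log units; that floor lies within the scatter), which cannot be placed beyond the scatter given that compound 1 is a limit. Compound 4 is expected to give about 30000 nM, in the range 10000 nM to 100000 nM.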

Compound 4, half-maximal inhibitory concentration: 29200 nM
Beside the measured number, compound 4's estimate is 1.0-fold (0.01 log units) above it; low and high end bracket the measured number.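

With 4-fluorophenyl in place of pyridin-4-yl on a double-bonded chain carbon bound to a double-bonded chain carbon, the shared core returns a number in this assay, which compound 1 does not. The change can be read only as an at least 1.3-fold lower number from compound 1 to compound 4 (0.13 log units; that floor lies within the scatter), and its true size cannot be fixed because compound 1 stands at a limit of the assay: the limit of > 40000 nM in this assay, at which 2 of the 4 values shown sit. Fluoro in place of trifluoromethyl on an aromatic carbon gives a 1.4-fold higher number from compound 3 to compound 4 (0.15 log units; within the scatter), so these two groups cannot be told apart in this assay.

As far as these compounds go, what an amine or a carboxylic acid would give in place of fluoro on that aromatic carbon remains open. From the compounds shown here alone, the true size of the step away from pyridin-4-yl also remains unknown.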